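The source may report more compounds than this note shows. Statements on the series, on what has been measured and on what is new or still open speak of the compounds shown alone.

Working notes on the series: three amides of the shared core have numbers so far in a functional assay on Caco-2 cells (Homo sapiens), read by MTT assay, with a stated time of 48 h; a lower number here means a stronger inhibitor, a higher number a weaker inhibitor. Compound 1 (`CCOC(=O)CN(C)C(=O)c1ccc(C(CC)(CC)c2ccc(OCC(O)C(C)(C)C)c(C)c2)n1CC`) gives 12200 nM, compound 2 (`CCn1c(C(=O)NCCN(C)C)ccc1C(CC)(CC)c1ccc(OCC(O)C(C)(C)C)c(C)c1`) gives 1300 nM, and compound 3 (`CCN(CC)CCCNC(=O)c1ccc(C(CC)(CC)c2ccc(OCC(O)C(C)(C)C)c(C)c2)n1CC`) gives 1800 nM. The number for compound 3 cannot be separated from its closest neighbour, with a 1.4-fold higher number from compound 2 to compound 3 (0.14 log units; within the scatter). It stands clearly apart from the highest number, with a 6.8-fold lower number from compound 1 to compound 3 (0.83 log units; beyond the scatter).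

Compound 4 (`CCn1c(C(=O)NCC(OC)OC)ccc1C(CC)(CC)c1ccc(OCC(O)C(C)(C)C)c(C)c1`) differs from compound 3 by dimethoxymethyl in place of 2-(diethylamino)ethyl on a saturated chain carbon bound to an amide-type nitrogen. The entering group has no nitrogen, so the amine of the side chain is lost.

The swap between the two amine chains moved nothing beyond the scatter and offers little guidance here. The relevant comparisons are the modest 9.4-fold lower number from compound 1 to compound 2 (0.97 log units; beyond the scatter) and the modest 6.8-fold lower number from compound 1 to compound 3 (0.83 log units; beyond the scatter), each replacing the amine-free chain of compound 1 with an amine chain. Compound 4 also lacks an amine, but it has no ester and retains the amide hydrogen of compound 3, so only part of that difference is expected to return in this assay.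

The expected change is a 3.1-fold higher number from compound 3 to compound 4 (0.49 log units; beyond the scatter), a modest rise. The estimate for compound 4 is 5500 nM, with an expected range of 2200 nM to 14000 nM.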

Compound 4, half-maximal inhibitory concentration: > 50000 nM
Compound 4 ended at the assay's limit (the forecaster's own chance of this, stated with the estimate: 5%); middle value at least 9.0-fold (0.95 log units) away from the limit.
By their numbers in this assay, from the lowest: compounds 2 and 3 (each within the scatter of the next); then compound 1. At a limit, above all of these: compound 4.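

In this assay compound 4 stands at a limit and not at a number: the limit of > 50000 nM in this assay, at which 1 of the 4 values shown sits. On the saturated chain carbon bound to an amide-type nitrogen, dimethoxymethyl in place of the amine chains moves the number further than any earlier step, with an at least 27-fold higher number from compound 3 to compound 4 (1.44 log units; beyond the scatter) and an at least 38-fold higher number from compound 2 to compound 4 (1.58 log units; beyond the scatter). The two amine-free chains are also not equivalent: although compound 4 keeps the amide hydrogen and has no ester, the result is an at least 4.0-fold higher number from compound 1 to compound 4 (0.61 log units; beyond the scatter), so among the compounds shown the amine chains hold the low numbers and neither amine-free chain comes near them.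

The compounds shown do not separate the loss of the amine from the arrival of the two methoxy groups, and a plain butyl or 3-methoxypropyl chain on the amide nitrogen would bear on that question. On these data alone, how far compound 4 lies past its limit also stays open, as does whether a cyclic amine such as piperidine or morpholine, or a carboxylic acid, at the end of the chain would keep or lose the numbers of the open-chain amines.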